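Methyl in place of iodo: compound 4 expected

A few compounds are considered here, and "the series" means these few. Any claim that something is new, unique, unknown or untested is made for them only; others in the source may bear on it.

Measured so far in a functional assay on HL-60 cells (Homo sapiens) for antiproliferative activity, with a stated time of 24 h; a lower number here means a stronger inhibitor, a higher number a weaker inhibitor:
- compound 1 `NC(=O)c1c(NC(=O)c2ccccc2Cl)sc2c1CCN(Cc1c(Cl)cccc1Cl)C2` gives 4850 nM
- compound 2 `NC(=O)c1c(NC(=O)c2ccccc2Cl)sc2c1CCN(Cc1ccc(Cl)cc1Cl)C2` gives 8010 nM
- compound 3 `NC(=O)c1c(NC(=O)c2ccccc2Cl)sc2c1CCN(C(=S)Nc1ccccc1I)C2` gives 4430 nM

Compound 3 holds the lowest of the three numbers, yet none of the gaps to it is more than scatter: a 1.1-fold lower number from compound 1 to compound 3 (0.04 log units; within the scatter) and a 1.8-fold lower number from compound 2 to compound 3 (0.26 log units; within the scatter). For the measured compounds named here, the only other measured step, a 1.7-fold higher number from compound 1 to compound 2 (0.22 log units; within the scatter), also stays within the scatter. All three compounds therefore sit at the same level in this assay, and no substituent change tried so far has moved the number.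

Compound 4 `Cc1ccccc1NC(=S)N1CCc2c(sc(NC(=O)c3ccccc3Cl)c2C(N)=O)C1` differs from compound 3 by methyl in place of iodo on an aromatic carbon. Going by the values given here, no measured step bears directly on this position; the measured steps swap the whole group on the ring amine nitrogen or shift chlorines on the benzyl ring, and each of them stayed within the scatter. With nothing pointing either way, the step is expected to be small: a 1.2-fold higher number from compound 3 to compound 4 (0.09 log units; within the scatter). Compound 4 is therefore estimated at 5500 nM, with a range from 2500 nM to 12000 nM.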

Compound 4, half-maximal inhibitory concentration: 22600 nM
For compound 4 the middle estimate is 4.1-fold (0.61 log units) below the measured one; measured number outside the range, above it.
By their numbers in this assay, from the lowest: compounds 3, 1 and 2 (each within the scatter of the next); then compound 4.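

In this assay, for the compounds shown here, the change from 2-iodophenyl to 2-methylphenyl gives the first step beyond the scatter: a 5.1-fold higher number from compound 3 to compound 4 (0.71 log units; beyond the scatter). This aromatic carbon, ortho to a large group, is thus a place where the substituent matters, and methyl gives a weaker inhibitor than iodo; compound 4 also separates from the other two compounds, with a 2.8-fold higher number from compound 2 to compound 4 (0.45 log units; beyond the scatter) and a 4.7-fold higher number from compound 1 to compound 4 (0.67 log units; beyond the scatter), whereas compound 3 stays within the scatter of both, so the swap on the ring amine nitrogen does not set the level by itself. No measurement available here accounts for the step.

Open, from the compounds shown here alone, is how hydrogen, chloro, bromo or methoxy at this carbon would compare with iodo and methyl. Also open, going by these compounds, is whether any other substituent here matches iodo.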